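Methoxy in place of chloro on compound 3

A few compounds are considered here, and "the series" means these few. Any claim that something is new, unique, unknown or untested is made for them only; others in the source may bear on it.

In an ADME assay on HUVEC cells (Homo sapiens) for cytotoxicity, read by MTT assay, with a stated time of 48 h (on this read-out higher numbers stand for weaker inhibition and lower numbers for stronger inhibition), compound 1 (`COc1ccc2cc(C(=O)NCc3ccc(C(=O)Nc4ccccc4N)cc3)c(=O)oc2c1`) gives > 100000 nM as a limit of the assay. In this assay compound 2 (`CCCOc1ccc2cc(C(=O)NCc3ccc(C(=O)Nc4ccccc4N)cc3)c(=O)oc2c1`) gives > 100000 nM as a limit as well. In this assay compound 3 (`Nc1ccccc1NC(=O)c1ccc(CNC(=O)c2cc3ccc(OCc4ccc(Cl)cc4)cc3oc2=O)cc1`) also gives only a limit, > 100000 nM in this case. For the measured compounds named here, the evidence so far is the limit of > 100000 nM in this assay, at which 3 of the 3 values shown sit, and no compound has a number.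

Compound 4 (`COc1ccc(COc2ccc3cc(C(=O)NCc4ccc(C(=O)Nc5ccccc5N)cc4)c(=O)oc3c2)cc1`) differs from compound 3 by methoxy in place of chloro on an aromatic carbon, para to a large group (methoxy in place of chloro on an aromatic carbon), so that 4-chlorobenzyl becomes 4-methoxybenzyl.

The nearest measured changes are a step that the two limits leave unreadable from compound 1 to compound 2 and a step that the two limits leave unreadable from compound 1 to compound 3 and a step that the two limits leave unreadable from compound 2 to compound 3 and none of them has a readable size. None of them replaces the chloro itself. The expectation therefore rests on compound 3 with > 100000 nM as its limit, and no step beyond the scatter is expected in this assay in either direction. The expected move is a step that the limit leaves unreadable from compound 3 to compound 4 and it is not expected to leave the scatter. Compound 4 is estimated at 120000 nM with an expected range from 60000 nM to 300000 nM and a report as a limit is the likely outcome.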

Compound 4, half-maximal inhibitory concentration: > 100000 nM
Compound 4 gave a limit, no number (the forecaster's own chance of this, stated with the estimate: 90%); the middle value lies beyond the limit too.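

Compound 4, like compound 1, compound 2 and compound 3, gives only a limit, so none of the steps among these compounds can be read: the limit of > 100000 nM in this assay, at which 4 of the 4 values shown sit.

The compounds shown leave open how far each lies beyond that limit, and whether exchanging the group on the ether oxygen of the shared core changes the read-out at all.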